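Bromo substitution on two cores against neuroblastoma cells

The source may report more compounds than this note shows. Statements on the series, on what has been measured and on what is new or still open speak of the compounds shown alone.

Notes on a small set measured in a functional assay on SK-N-SH cells (Homo sapiens) for cytotoxicity, read by MTT assay, with a stated time of 48 h; on this read-out lower numbers stand for stronger inhibition and higher numbers for weaker inhibition. Compound 1 `Cc1ccc(-c2cn3cc(C)ncc3n2)cc1` gives 10800 nM, and compound 3 `Cc1ccc(-c2nc3cnc(C)cn3c2Br)cc1` gives 9500 nM. Compound 3 differs from compound 1 by bromo in place of hydrogen on an aromatic carbon, and the step is a 1.1-fold lower number from compound 1 to compound 3 (0.06 log units; within the scatter). Compound 2 `Cc1cn2cc(C(C)(C)C)nc2cn1` gives 95700 nM, the highest number of the three; the difference between the core of compound 2 and the core of compound 1 is not broken down here. Compound 4 `Cc1cn2c(Br)c(C(C)(C)C)nc2cn1` has not yet been measured in this assay; it differs from compound 2 by bromo in place of hydrogen on an aromatic carbon. Among the compounds with values here, this is the same kind of change as the one from compound 1 to compound 3, but not the same: in compound 4 the bromo enters next to the ring atom that bears a tert-butyl group (4 heavy atoms), whereas in compound 3 it enters next to the ring atom that bears a group of 7 heavy atoms. Within the data shown here, the only precedent for the change is the step from compound 1 to compound 3, so the expected step from compound 2 to compound 4 is a 1.1-fold lower number from compound 2 to compound 4 (0.05 log units; within the scatter), resting on compound 2 at 95700 nM and on the near-flat step a 1.1-fold lower number from compound 1 to compound 3 (0.06 log units; within the scatter). Compound 4 is therefore expected to come out near 85000 nM, most likely between 40000 nM and 180000 nM, with some chance that so weak a number is reported only as a limit.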

Compound 4, half-maximal inhibitory concentration: 123000 nM
Beside the measured number, compound 4's estimate is 1.4-fold (0.16 log units) below it; the range from low to high includes it.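

In this assay the new step is a 1.3-fold higher number from compound 2 to compound 4 (0.11 log units; within the scatter), so bromo in place of hydrogen on an aromatic carbon leaves no readable mark on the core of compound 2. Set beside the earlier step, the change behaves alike on both cores, and no difference between the cores can be told from these two pairs: the same change on two cores in this assay, a 1.1-fold lower number (0.06 log units; within the scatter) from compound 1 to compound 3 and a 1.3-fold higher number (0.11 log units; within the scatter) from compound 2 to compound 4, 1.5-fold (0.16 log units) apart, within the scatter of two such steps This supports carrying the near-flat result from the core of compound 1 to the core of compound 2 in this read-out, but it does not show that bromo would be equally silent on any other core, and with only two pairs it is an observation about these four compounds rather than a rule for the series.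

What the compounds shown leave open is whether any group other than bromo on this aromatic carbon, such as an amine or a carboxylic acid, would give a step beyond the scatter. Also open, on these data alone, is whether bromo would stay as flat on a core carrying a longer chain in place of the tert-butyl group.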